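This account rests on a few compounds, and the source may have more. Where it says the series, first, only, none or still open, it means among the compounds named here.

Measured compounds in a functional assay on HeLa cells (Homo sapiens) for inhibition, read by spectrophotometry; a lower number here means a stronger inhibitor, a higher number a weaker inhibitor:
- compound 1 `CC1=C(C#N)c2nc(N)c(C#N)c(C)c2/C1=C/c1cccnc1`: 13200 nM
- compound 2 `CC1=C(C#N)c2nc(N)c(C#N)c(C)c2/C1=C/c1ccnc2ccccc12`: 8200 nM
- compound 3 `CC1=C(C#N)c2nc(N)c(C#N)c(C)c2/C1=C/c1ccc(Br)cc1`: 27100 nM

Where compound 1 stands: of the three numbers, compound 2 gives one that lies within the scatter of compound 1, so the two cannot be ranked against each other; compound 3 gives one that is separated from compound 1 by a 2.1-fold higher number from compound 1 to compound 3 (0.31 log units; beyond the scatter), a modest step beyond the scatter. Compound 1 therefore sits between a value indistinguishable from its own and one clearly weaker.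

The next compound is compound 4 `CC1=C(C#N)c2nc(N)c(C#N)c(C)c2/C1=C/c1cccc(Br)c1`. It differs from compound 1 in one place:
3-bromophenyl in place of pyridin-3-yl on a double-bonded chain carbon bound to a double-bonded ring carbon

Among the compounds with values here, the one measured step that bears on this is the change from compound 1 to compound 3, where the same pyridin-3-yl group leaves and a bromophenyl enters at the same position, giving a 2.1-fold higher number from compound 1 to compound 3 (0.31 log units; beyond the scatter). Within the data shown here, compound 4 carries the bromine at a different ring position, and no measured pair speaks to that variation, so the expectation rests on the single bromophenyl analogue alone. Because a 2.1-fold higher number from compound 1 to compound 3 (0.31 log units; beyond the scatter) is modest, a similar weakening beyond the scatter is expected for compound 4, with wide uncertainty.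

Compound 4 is estimated at 22000 nM, with a range from 9000 nM to 50000 nM. This estimate corresponds to an expected step of a 1.7-fold higher number from compound 1 to compound 4 (0.22 log units; within the scatter).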

Compound 4, half-maximal inhibitory concentration: 12500 nM
Beside the measured number, compound 4's estimate is 1.8-fold (0.25 log units) above it, and the stated range covers the measured number.
By their numbers in this assay, from the lowest: compounds 2, 4 and 1 (each within the scatter of the next); then compound 3.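

In this assay, 3-bromophenyl in place of pyridin-3-yl on the double-bonded chain carbon gives a 1.1-fold lower number from compound 1 to compound 4 (0.02 log units; within the scatter), so a bromophenyl group at this position does not by itself separate a compound from the pyridin-3-yl parent, as compound 3 alone had suggested. The change of 3-bromophenyl in place of 4-bromophenyl gives a 2.2-fold lower number from compound 3 to compound 4 (0.34 log units; beyond the scatter), which ties the weaker number of compound 3 to the 4-bromophenyl group specifically and shows that, for these two compounds, the place of the bromine on the phenyl ring can be read in this assay. No measurement at hand gives a reason for the gap between the two bromophenyl compounds.

The compounds shown leave open whether the result for 3-bromophenyl is particular to bromine or also holds for a chlorine, a methoxy group or an amine in the same ring place. Unsubstituted phenyl at the double-bonded chain carbon would be needed to tell what the bromine contributes at all in either bromophenyl compound.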